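Removing the Iodo Group from Compound 2

This account rests on a few compounds, and the source may have more. Where it says the series, first, only, none or still open, it means among the compounds named here.

Of the compounds shown here, three sharing one core have been tested in a functional assay on OVCAR-4 cells (Homo sapiens) for inhibition; on this read-out higher numbers stand for weaker inhibition of growth and lower numbers for stronger inhibition of growth. Compound 1, with structure `Cc1cc(-c2nc3cc(F)c(F)cc3s2)ccc1N`, gives 60300 nM in this assay. Compound 3, with structure `Nc1ccc(-c2nc3ccc(F)cc3s2)cc1Cl`, gives 20 nM. Compound 2, with structure `Nc1ccc(-c2nc3cc(F)ccc3s2)cc1I`, reaches only the limit of the assay, < 10 nM, so no exact number is known for it. This leaves compound 2 at one end of the values shown, as the limit of < 10 nM in this assay, at which 1 of the 3 values shown sits, states, while compound 1 sits far toward the weak end and compound 3 lies close to compound 2.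

Compound 4, with structure `Nc1ccc(-c2nc3cc(F)ccc3s2)cc1`, has not yet been measured. It differs from compound 2 in one place only: hydrogen in place of iodo on an aromatic carbon. The iodo group that sits ortho to the amino group in compound 2 is gone, and a hydrogen atom takes its place.

Going by the values given here, no measured pair here differs in just this way, so the size of the step cannot be read from the data. Since both compound 2 and compound 3 carry a halogen at this place and both are potent, while compound 4 carries none, a step toward weaker growth inhibition, clearly beyond the scatter, is expected. The step from compound 2 to compound 4 is estimated at an at least 50-fold higher number from compound 2 to compound 4 (1.69 log units; beyond the scatter). Compound 4 is expected to give 500 nM in this assay, within a range from 50 nM to 5000 nM.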

Compound 4, concentration for 50% growth inhibition: 13500 nM
Beside the measured number, compound 4's estimate is 27-fold (1.43 log units) below it, and the stated range ends below it.
By their numbers in this assay, from the lowest: compound 3; then compound 4; then compound 1. At a limit, below all of these: compound 2.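

Replacing iodo with hydrogen on this aromatic carbon, ortho to the amino group, gives an at least 1300-fold higher number from compound 2 to compound 4 (3.13 log units; beyond the scatter) in this assay. Going by these compounds alone, none of the earlier compounds formed a pair differing in one place, so this is the first direct measure of what this position contributes: losing one iodine atom, with the rest of the molecule unchanged, turns a very strong inhibitor of growth into a far weaker one. Compound 2 is recorded only as a limit and not as an exact number, which is why this step is stated as a minimum: the limit of < 10 nM in this assay, at which 1 of the 4 values shown sits.

Still open, on these data alone, is how other groups would behave on this carbon of compound 4, such as a bromo group, a nitrile or a hydroxyl group, and so whether iodo is special or many groups would serve here. Chloro in compound 3 and methyl in compound 1 sit at this same place, but these two compounds also differ from compound 4 in their fluorine atoms, so they cannot settle the question.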